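Chloro for Fluoro on a Fused Aromatic Ring: Cytotoxicity

A few compounds are considered here, and "the series" means these few. Any claim that something is new, unique, unknown or untested is made for them only; others in the source may bear on it.

Compound 1 `CONC(=S)N/N=C1\C(=O)N(CN2CCN(c3ccccc3)CC2)c2ccc(F)cc21`: 227000 nM
Compound 2 `CONC(=S)N/N=C1\C(=O)N(CN2CCN(c3c(F)cc4c(=O)c(C(=O)O)cn(C5CC5)c4c3OC)CC2C)c2ccc(F)cc21`: 171000 nM
Compound 3 `CONC(=S)N/N=C1\C(=O)N(CN2CCN(c3ccccc3)CC2)c2ccc(Cl)cc21`: 267000 nM

Three compounds were measured in an ADME assay on MT4 cells (Homo sapiens) for cytotoxicity, read by spectrophotometry, with a stated time of 5 days; a higher number here means that more compound is tolerated, a lower number that less compound is tolerated. Compound 1 gives 227000 nM in this assay, and compound 3 gives 267000 nM. The change between them, (chloro in place of fluoro on an aromatic carbon), made the step of a 1.2-fold higher number from compound 1 to compound 3 (0.07 log units; within the scatter). Compound 2 gives 171000 nM in this assay; the difference between the core of compound 2 and that of compound 1 is not broken down here. Compound 4 `CONC(=S)N/N=C1\C(=O)N(CN2CCN(c3c(F)cc4c(=O)c(C(=O)O)cn(C5CC5)c4c3OC)CC2C)c2ccc(Cl)cc21` has not yet been measured in this assay. It differs from compound 2 by chloro in place of fluoro on an aromatic carbon, the same change as that from compound 1 to compound 3. On that basis a step of about a 1.2-fold higher number from compound 2 to compound 4 (0.07 log units; within the scatter) is expected, because the earlier step of a 1.2-fold higher number from compound 1 to compound 3 (0.07 log units; within the scatter) stayed small. Compound 4 is therefore expected to give about 200000 nM in this assay, between 100000 nM and 400000 nM.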

Compound 4, half-maximal cytotoxic concentration: 164000 nM
Beside the measured number, compound 4's estimate is 1.2-fold (0.09 log units) above it; the measured number falls inside the stated range.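

In this assay, chloro in place of fluoro on an aromatic carbon gave a 1.0-fold lower number from compound 2 to compound 4 (0.02 log units; within the scatter). Set beside the earlier step, the change carried from one core to the other without a difference that can be told apart: the same change on two cores in this assay, a 1.2-fold higher number (0.07 log units; within the scatter) from compound 1 to compound 3 and a 1.0-fold lower number (0.02 log units; within the scatter) from compound 2 to compound 4, 1.2-fold (0.09 log units) apart, within the scatter of two such steps. This shows that the exchange stayed within the scatter on both cores, but it gives the change no direction, and two cores cannot show that it would carry to others in this series. The compounds shown leave open whether bromo, methoxy or a nitrile on that aromatic carbon would behave alike. They also leave open whether the step would hold on a core bearing a primary amine or a longer alkyl chain.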